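Swapping an Amide for an Ester on a Shared Core

The source may hold more compounds than are shown below. What is called first, only, known or untested is meant among the compounds shown, and "the series" means these compounds.

Of the compounds shown here, three built on one shared core have been tested in an assay on HL-60 cells for agonist activity at vitamin D3 receptor (Homo sapiens), read by microscopy, with a stated time of 96 h; on this read-out lower numbers stand for an effect already at smaller amounts and higher numbers for an effect only at larger amounts of compound. Compound 1 `CCN(CC)CCNC(=O)c1ccc(C(CC)(CC)c2ccc(OCC(O)C(C)(C)C)c(C)c2)n1CC` gives 110 nM, compound 2 `CCN(CC)CCCNC(=O)c1ccc(C(CC)(CC)c2ccc(OCC(O)C(C)(C)C)c(C)c2)n1CC` gives 66 nM, and compound 3 `C=CCN(C)C(=O)c1ccc(C(CC)(CC)c2ccc(OCC(O)C(C)(C)C)c(C)c2)n1CC` gives 3950 nM, the highest of the three numbers. The steps of a 36-fold higher number from compound 1 to compound 3 (1.56 log units; beyond the scatter) and a 60-fold higher number from compound 2 to compound 3 (1.78 log units; beyond the scatter) show how sharply the number rose when a (2-(diethylamino)ethyl)amino or (3-(diethylamino)propyl)amino group gave way to allyl(methyl)amino. Compound 4 `C#CC(C)OC(=O)c1ccc(C(CC)(CC)c2ccc(OCC(O)C(C)(C)C)c(C)c2)n1CC` differs from compound 3 by (1-methylprop-2-yn-1-yl)oxy in place of allyl(methyl)amino on a carbonyl carbon; like compound 3, it carries neither of those two groups. For the measured compounds named here, no measured step turns an amide into an ester, so the nearest guide is compound 3 alone. Compound 4 is therefore expected to stay near that level, a step of a 1.0-fold higher number from compound 3 to compound 4 (0.01 log units; within the scatter) in this assay, giving an estimated 4000 nM with a range from 1000 nM to 16000 nM.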

Compound 4, half-maximal effective concentration: 200 nM
Compound 4: the middle estimate sits 20-fold (1.30 log units) above what was measured; measured number outside the range, below it.
By their numbers in this assay, from the lowest: compounds 2, 1 and 4 (each within the scatter of the next, the first and the last beyond it); then compound 3.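

In this assay, a group with no diethylamino end on the carbonyl carbon can still give a low number: the step is a 20-fold lower number from compound 3 to compound 4 (1.30 log units; beyond the scatter), so compound 3 does not speak for all such groups. Against the diethylamino amides, the change reads a 3.0-fold higher number from compound 2 to compound 4 (0.48 log units; beyond the scatter) and a 1.8-fold higher number from compound 1 to compound 4 (0.26 log units; within the scatter). No measured evidence accounts for these steps.

Going by these compounds, it remains open whether the oxygen or the triple bond matters more. An amide bearing (1-methylprop-2-yn-1-yl)amino, or an ester bearing allyloxy, would separate the two.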